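Adding a Third Fluorine to the Anilide Ring

The compounds below may be only part of what the source reports. "The series", "measured", "known", "first", "only" and "open" are said of these compounds alone.

Compound 1, `Cc1cccc(C)c1NC(=O)CC(=O)Oc1c(C(C)C)cccc1C(C)C`, in an assay on microsomes from intestine for inhibition of acyl-CoA:cholesterol acyltransferase (Oryctolagus cuniculus) (on this read-out lower numbers stand for stronger inhibition and higher numbers for weaker inhibition), gives 210 nM.
Compound 2, `CC(C)c1cccc(C(C)C)c1OC(=O)CC(=O)Nc1ccccc1`, in this assay gives > 5000 nM, which is a limit of the assay rather than a number.
Compound 3, `CC(C)c1cccc(C(C)C)c1OC(=O)CC(=O)Nc1c(F)cccc1F`, in this assay gives 6200 nM.

Of the two numbers in hand, compound 3 holds the higher one; the nearest is compound 1, and the step is a 30-fold higher number from compound 1 to compound 3 (1.47 log units; beyond the scatter). The step of an at least 23-fold higher number from compound 1 to compound 2 (1.37 log units; beyond the scatter) runs in the same direction, and the pair compound 2 to compound 3 shows only a step that the limit leaves unreadable from compound 2 to compound 3, as the limit of > 5000 nM in this assay, at which 1 of the 3 values shown sits, sets a floor under compound 2.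

Compound 4, `CC(C)c1cccc(C(C)C)c1OC(=O)CC(=O)Nc1c(F)cc(F)cc1F`, is not yet measured. It differs from compound 3 by fluoro in place of hydrogen on an aromatic carbon. Within the data shown here, no measured step adds a fluoro to a 2,6-difluorophenyl ring; the two readable steps both replace the whole ring on the amide nitrogen and both are large. For compound 4 the change is smaller and a step of a 1.1-fold higher number from compound 3 to compound 4 (0.05 log units; within the scatter) is expected, within the usual scatter. Compound 4 is therefore estimated at 7000 nM, between 2500 nM and 20000 nM.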

Compound 4, half-maximal inhibitory concentration: > 5000 nM
Compound 4 was reported as a limit; the forecaster's own chance of this, stated with the estimate: 35%; the middle value lies beyond the limit too.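

In this assay compound 4 gives > 5000 nM, which is a limit of the assay and not a number. With 2,4,6-trifluorophenyl in place of 2,6-dimethylphenyl on the amide nitrogen, the result is an at least 23-fold higher number from compound 1 to compound 4 (1.37 log units; beyond the scatter), so a third ring without the two methyl groups also falls far short of compound 1. The steps from compound 2 and from compound 3 to compound 4 cannot be read, so nothing can be said about what the new fluoro, para to a large group, does on its own: the limit of > 5000 nM in this assay, at which 2 of the 4 values shown sit.

Still open, as far as these compounds go, is whether a fluoro at this ring carbon would change anything on the 2,6-dimethylphenyl ring of compound 1, which gives a real number. From the compounds shown here alone, how a methyl or a methoxy group at the same carbon would read on either ring also remains unknown.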